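Swapping a carboxyphenyl on the amide nitrogen

The compounds below may be only part of what the source reports. "The series", "measured", "known", "first", "only" and "open" are said of these compounds alone.

Measured compounds:
compound 1, `CCCCCCCCCCOc1cc(OCCCCCCCCCC)cc(OCCCCCC(=O)N(c2ccc(C(=O)O)cc2)c2cccc(C(=O)O)c2)c1`, 53% in an assay on isolated protein for binding affinity to L-selectin (Homo sapiens), read by ELISA, tested at 500 uM; a lower number here means less inhibition, a higher number more inhibition at the concentration tested (going by the name of the read-out)
compound 2, `CCCCCCCCCCOc1cc(OCCCCCCCCCC)cc(OCCCCCCN(Cc2ccc(C(=O)O)cc2)c2ccc(C(=O)O)cc2)c1`, "not determined" (no result reported) in this assay

Going by the values given here, compound 1 is the only compound of the set with a number in this assay: it gives 53%, which places it at roughly half inhibition at the tested concentration. Compound 2 shares the long-chain core but carries no result, so it offers no comparison and nothing can be said of the distance between the two.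

The step considered here leads from compound 1 to compound 3, `CCCCCCCCCCOc1cc(OCCCCCCCCCC)cc(OCCCCCC(=O)N(c2cccc(C(=O)O)c2)c2cccc(C(=O)O)c2)c1`. The difference is counted as 3-carboxyphenyl in place of 4-carboxyphenyl on an amide-type nitrogen. Nothing changes in what is counted; only the attachment point of the carboxylic acid on one aryl ring moves, and the second ring on that nitrogen already carries its acid in the same pattern.

Among the compounds with values here, with no step between measured compounds available, the expected size of the change in this assay rests on the structural change alone. Because compound 1 gives 53% and the rearrangement is small, compound 3 is expected to stay close, with a step of a number 3 percentage points lower from compound 1 to compound 3 (within the scatter) that need not exceed the scatter. Compound 3 is therefore estimated at 50%, within a range from 30% to 70%.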

Compound 3, a percentage reported as inhibition, at one concentration (the size of the read-out at that concentration, not a potency): 14%
The estimate for compound 3 lay 36 percentage points above the measured number, outside the stated range (below it).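

Moving the acid on one ring of the amide-type nitrogen proved far from neutral in this assay as 3-carboxyphenyl in place of 4-carboxyphenyl gives a number 39 percentage points lower from compound 1 to compound 3 (beyond the scatter) even though the atoms counted stay the same. Going by these compounds alone, the earlier compounds offered no measured step, so this is the first sign that inhibition at the tested concentration responds to the attachment point of the acid on this ring. At this nitrogen, the pairing of one 4-carboxyphenyl with one 3-carboxyphenyl reads higher than two 3-carboxyphenyl groups, and no measurement at hand bears on why the number falls.

The compounds shown leave open how 2-carboxyphenyl or two 4-carboxyphenyl groups on the same nitrogen would read, and whether the trend seen in this single pair would continue. They also leave open whether the carboxylic acid on this ring is needed at all, as a ring with a tetrazole or an amine in its place, or an unsubstituted phenyl, would be needed to answer that.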